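Nitro Addition on a Benzimidazole Cytotoxicity Series

The source may hold more compounds than are shown below. What is called first, only, known or untested is meant among the compounds shown, and "the series" means these compounds.

Compound 1 `COc1ccc(-c2nc3cc(Cl)c(Cl)cc3[nH]2)cc1` gives 1000 nM. Compound 2 `O=[N+]([O-])c1ccc(-c2nc3cc(C(F)(F)F)ccc3[nH]2)cc1` gives 6000 nM. Compound 3 `O=[N+]([O-])c1ccc(-c2nc3cc(C(F)(F)F)ccc3[nH]2)c([N+](=O)[O-])c1` gives 9000 nM.

These three compounds were measured in an ADME assay on MT4 cells (Homo sapiens) for cytotoxicity, read by MTT assay, with a stated time of 96 h; on this read-out higher numbers stand for lower toxicity in this test and lower numbers for higher toxicity in this test. Compound 1 has the lowest number of the three, and its gap to compound 2 and to compound 3 is beyond the scatter. The difference between the core of compound 1 and the core of compound 2 is not broken down here. From compound 2 to compound 3 the change is nitro in place of hydrogen on an aromatic carbon and gave a 1.5-fold higher number from compound 2 to compound 3 (0.18 log units; within the scatter). Compound 4 `COc1ccc(-c2nc3cc(Cl)c(Cl)cc3[nH]2)c([N+](=O)[O-])c1` differs from compound 1 by nitro in place of hydrogen on an aromatic carbon. This is the same kind of change, but the place differs: meta to a methoxy group in compound 4, meta to a nitro group in compound 3. Resting on the step from compound 2 to compound 3, the step from compound 1 to compound 4 in this assay is expected to be a 1.4-fold higher number from compound 1 to compound 4 (0.15 log units; within the scatter). Compound 4 is therefore estimated at 1400 nM, with a likely range from 600 nM to 3500 nM.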

Compound 4, half-maximal cytotoxic concentration: 2000 nM
The estimate for compound 4 lay 1.4-fold (0.15 log units) below the measured number; the range from low to high includes it.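

In this assay the nitro in place of hydrogen on the core of compound 1 gave a 2.0-fold higher number from compound 1 to compound 4 (0.30 log units; within the scatter) and so stays inside the usual scatter. The same change reads alike on the two cores: the same change on two cores in this assay, a 1.5-fold higher number (0.18 log units; within the scatter) from compound 2 to compound 3 and a 2.0-fold higher number (0.30 log units; within the scatter) from compound 1 to compound 4, 1.3-fold (0.12 log units) apart, within the scatter of two such steps. This shows that neither pair gives a step that can be told from the scatter, but it does not show that nitro leaves the number unchanged on other cores, and two pairs with the nitro in different surroundings set no rule for the series.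

The compounds shown leave open whether an amine or a carboxylic acid on the same aromatic carbon would give a step beyond the scatter. They also leave open how a second nitro would read on other cores.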